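The source may report more compounds than this note shows. Statements on the series, on what has been measured and on what is new or still open speak of the compounds shown alone.

The series shares the core seen in compound 1 `c1ccc(Sc2cncc(N3CCCNCC3)c2)cc1`, which in an assay on cell membranes for binding affinity to Neuronal acetylcholine receptor; alpha4/beta2 (Rattus norvegicus), read by radioligand binding (a lower number here means a stronger inhibitor, a higher number a weaker inhibitor), gives 4 nM. Of the three measured compounds, compound 1 sits in the middle: compound 3 `OCCOc1cncc(N2CCCNCC2)c1` gives 1.8 nM, and compound 2 `NC(=O)c1cncc(N2CCCNCC2)c1` gives 20 nM. For the measured compounds named here, the only single-point step measured so far is an 11-fold lower number from compound 2 to compound 3 (1.05 log units; beyond the scatter), a change on an aromatic carbon of the core. Compound 4 `C1=CC(CSc2cncc(N3CCCNCC3)c2)C=C1` differs from compound 1 at a different place: a group of 6 heavy atoms (6 carbon; one five-membered non-aromatic ring of carbon only) in place of a group of 6 heavy atoms (6 carbon; one six-membered aromatic ring of carbon only), on a sulfur. Going by the values given here, no measured step touches the group on the sulfur, so the step from compound 2 to compound 3 offers no direct guide, and the expected shift can only be set by how far the measured numbers spread around compound 1. A modest weakening is expected, the estimated step being a 1.8-fold higher number from compound 1 to compound 4 (0.24 log units; within the scatter), with a fair chance that it stays within the scatter. The estimate for compound 4 in this assay is 7 nM, expected to lie between 2 nM and 25 nM.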

Compound 4, half-maximal inhibitory concentration: 8 nM
For compound 4 the middle estimate is 1.1-fold (0.06 log units) below the measured one, within the range that was stated.
By their numbers in this assay, from the lowest: compound 3; then compounds 1 and 4 (each within the scatter of the next); then compound 2.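

In this assay the group on the sulfur tolerates a change of ring: the step of a 2.0-fold higher number from compound 1 to compound 4 (0.30 log units; within the scatter) shows that phenyl and a five-membered non-aromatic ring of carbon only, with 2 double bonds outside aromatic rings, cannot be told apart here. For the compounds shown here, this is the only step at this position, as the step of an 11-fold lower number from compound 2 to compound 3 (1.05 log units; beyond the scatter) concerned a group on an aromatic carbon, and it shows that an aromatic ring on the sulfur is not needed for a reading in this range. No measured evidence bears on why the two compounds read alike.

The compounds shown leave open how a saturated cyclopentyl ring, an amine or a carboxylic acid on the sulfur would read. They also leave open whether a longer chain placed there would keep the reading of compound 1.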